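A few compounds are considered here, and "the series" means these few. Any claim that something is new, unique, unknown or untested is made for them only; others in the source may bear on it.

Compound 1 `Clc1ccccc1CSc1nnc(-c2ccc3c(c2)OCCO3)n1-c1ccccc1` and compound 2 `Fc1ccc(CSc2nnc(-c3ccc4c(c3)OCCO4)n2-c2ccccc2)c(F)c1` share one core and differ only in the aryl group on the saturated chain carbon bound to a sulfur. In a functional assay on HeLa cells (Homo sapiens) for antiproliferative activity, read by MTT assay, with a stated time of 24 h (a lower number here means a stronger inhibitor, a higher number a weaker inhibitor), compound 1 gives 29000 nM, the highest of the two numbers available, while compound 2 gives 18600 nM; the step between them is a 1.6-fold lower number from compound 1 to compound 2 (0.19 log units; within the scatter). Compound 3 `Brc1ccc(CSc2nnc(-c3ccc4c(c3)OCCO4)n2-c2ccccc2)cc1` is the next variation at the same place: 4-bromophenyl in place of 2-chlorophenyl on a saturated chain carbon bound to a sulfur. Going by the values given here, the only measured step that bears on this change is the one from compound 1 to compound 2, which exchanged one halogenated phenyl for another at the same carbon and stayed within the scatter. On that basis no step beyond the scatter is expected for compound 3, and its value in this assay is estimated at 25000 nM, with a range from 8000 nM to 70000 nM, an expected step of a 1.2-fold lower number from compound 1 to compound 3 (0.06 log units; within the scatter).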

Compound 3, half-maximal inhibitory concentration: 54600 nM
Beside the measured number, compound 3's estimate is 2.2-fold (0.34 log units) below it, within the range that was stated.
By their numbers in this assay, from the lowest: compounds 2, 1 and 3 (each within the scatter of the next, the first and the last beyond it).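

In this assay this position now gives its first step beyond the scatter, a 2.9-fold higher number from compound 2 to compound 3 (0.47 log units; beyond the scatter), a modest one, for 4-bromophenyl in place of 2,4-difluorophenyl on a saturated chain carbon bound to a sulfur. The exchange of 2-chlorophenyl for 4-bromophenyl at the same carbon stays within the scatter, with a 1.9-fold higher number from compound 1 to compound 3 (0.27 log units; within the scatter), so compound 1 cannot be separated from either of the other two. Going by these compounds alone, the aryl group at this carbon can therefore shift the number, though only the pair of compound 2 and compound 3 shows it. No measurement at hand explains this difference.

As far as these compounds go, all three compounds carry a halogenated phenyl here, so it stays open how an unsubstituted phenyl, a methoxyphenyl or a pyridine ring would read. Compound 1 and compound 3 also differ in both the halogen and its place, and these two changes remain unseparated.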